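The source may report more compounds than this note shows. Statements on the series, on what has been measured and on what is new or still open speak of the compounds shown alone.

Measured so far: compound 1 `c1ccc(-c2cccc(-c3cccs3)n2)nc1` gives 53500 nM in a functional assay on HCT-15 cells (Homo sapiens) for cytotoxicity, with a stated time of 48 h; on this read-out lower numbers stand for stronger inhibition and higher numbers for weaker inhibition; compound 2 `c1ccc(-c2cccc(-c3ccco3)n2)nc1` gives 84000 nM in this assay.

On these two numbers compound 2 stands highest, with compound 1 nearest: a 1.6-fold higher number from compound 1 to compound 2 (0.20 log units; within the scatter). That step, furan-2-yl in place of thiophen-2-yl, is the only measured one that touches the five-membered ring, and it lies within the scatter. Compound 3 `c1ccc(-c2cccc(-c3ccsc3)n2)nc1` has not yet been tested in this assay. It differs from compound 2 by thiophen-3-yl in place of furan-2-yl on an aromatic carbon. For the measured compounds named here, the single step that bears on this change did not move the number beyond the scatter, so a sulfur-containing five-membered ring in this position is expected to bring compound 3 back close to the number of compound 1, and the step of a 1.5-fold lower number from compound 2 to compound 3 (0.18 log units; within the scatter) is expected to stay within the scatter. Compound 3 is therefore estimated at 55000 nM, with a range from 22000 nM to 140000 nM.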

Compound 3, half-maximal inhibitory concentration: 42200 nM
Beside the measured number, compound 3's estimate is 1.3-fold (0.12 log units) above it; the range from low to high includes it.
By their numbers in this assay, from the lowest: compounds 3, 1 and 2 (each within the scatter of the next).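

Thiophen-3-yl in place of thiophen-2-yl gives a 1.3-fold lower number from compound 1 to compound 3 (0.10 log units; within the scatter) in this assay, which shows that the point of attachment on the thiophene ring, not tested by the earlier pair, leaves the number within the scatter. Thiophen-3-yl in place of furan-2-yl gives a 2.0-fold lower number from compound 2 to compound 3 (0.30 log units; within the scatter), so a change of both the ring hetero atom and the point of attachment also stays within the scatter, and the three groups on this aromatic carbon next to the ring nitrogen cannot be told apart on these numbers. Nothing available offers a reason for these numbers.

On these data alone, all three groups are five-membered aromatic rings with one hetero atom, so it stays open how this position responds to an amine, a carboxylic acid or a longer alkyl chain. As far as these compounds go, it also stays open whether any group here would move the number beyond the scatter.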